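The source may hold more compounds than are shown below. What is called first, only, known or untested is meant among the compounds shown, and "the series" means these compounds.

In a functional assay on SW-620 cells (Homo sapiens) for cytotoxicity, read by MTT assay, with stated times of 4 h and 72 h, tested at 1 uM (a higher number here means a weaker inhibitor, a lower number a stronger inhibitor), compound 1 (`Cc1cc(Nc2ccc(C(=O)/C=C/c3cccc(Br)n3)cc2)n2nc(SCc3nc4ccccc4[nH]3)nc2n1`) gives 58 nM and compound 2 (`Cc1cc(Nc2ccc(C(=O)/C=C/c3ccc(Br)cn3)cc2)n2nc(SCc3nc4ccccc4[nH]3)nc2n1`) gives 110 nM, values within the scatter of each other, so neither is set apart. Compound 3 (`Cc1cc(Nc2ccc(C(=O)/C=C/c3ccc4ccccc4c3)cc2)n2nc(SCc3nc4ccccc4[nH]3)nc2n1`) has naphthalen-2-yl in place of 6-bromopyridin-2-yl on a double-bonded chain carbon bound to a double-bonded chain carbon. Going by the values given here, the only measured step, a 1.9-fold higher number from compound 1 to compound 2 (0.28 log units; within the scatter), lies within the scatter, but it exchanges one bromopyridinyl group for another and offers only weak guidance on a carbon-only two-ring group. No step beyond the scatter is therefore expected, and the estimated step is a 1.4-fold higher number from compound 1 to compound 3 (0.14 log units; within the scatter). For compound 3 the expected value is 80 nM, with an estimated range of 25 nM to 250 nM.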

Compound 3, half-maximal inhibitory concentration: 28.2 nM
Beside the measured number, compound 3's estimate is 2.8-fold (0.45 log units) above it, within the range that was stated.
By their numbers in this assay, from the lowest: compound 3; then compounds 1 and 2 (each within the scatter of the next).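

In this assay, the bromopyridinyl groups are not needed on the double-bonded chain carbon: naphthalen-2-yl, with two carbon-only rings, gives lower numbers (a 2.1-fold lower number from compound 1 to compound 3 (0.31 log units; beyond the scatter); a 3.9-fold lower number from compound 2 to compound 3 (0.59 log units; beyond the scatter)). Both steps are modest but beyond the scatter, so this position responds to a change of ring system more clearly than to the exchange between the two bromopyridinyl groups. No measurement on hand gives a cause for these steps.

Going by these compounds, the change removes the ring nitrogen and bromine and adds a second ring all at once, so their separate contributions remain open. Phenyl and quinolin-2-yl groups at this position would begin to separate them.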